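Adding a Second Chloro to a Fused Bicyclic Core

The source may report more compounds than this note shows. Statements on the series, on what has been measured and on what is new or still open speak of the compounds shown alone.

Measured so far:
- Compound 1 `ClCc1ccccc1Cn1cnc2c(Cl)ncnc21`: 38000 nM
- Compound 2 `ClCc1ccccc1Cn1cnc2ncnc(Cl)c21`: 12900 nM

Both compounds were tested in a functional assay on 786-0 cells (Homo sapiens) for cytotoxicity, read by sulforhodamine B assay, with a stated time of 48 h; a lower number here means a stronger inhibitor of growth, a higher number a weaker inhibitor of growth. Compound 2 has the lower of the two numbers, and compound 1 sits higher, a gap that lies beyond the usual scatter of this assay. Compound 2 is therefore the stronger growth inhibitor of the pair.

Compound 3 `ClCc1ccccc1Cn1cnc2nc(Cl)nc(Cl)c21` is not yet measured. It differs from compound 2 in one place: chloro in place of hydrogen on an aromatic carbon. For the measured compounds named here, no measured pair in this set shows what such an exchange does, so the direction and size of the step are open. A modest change is expected, leaning toward a lower number, since small additions on this core have so far shifted the value only moderately. The step from compound 2 to compound 3 is expected to be a 1.6-fold lower number from compound 2 to compound 3 (0.21 log units; within the scatter). For compound 3 the estimate is 8000 nM, within a range from 2500 nM to 25000 nM.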

Compound 3, concentration for total growth inhibition: 7070 nM
Compound 3: the middle estimate sits 1.1-fold (0.05 log units) above what was measured; measured number inside the range.
By their numbers in this assay, from the lowest: compounds 3 and 2 (each within the scatter of the next); then compound 1.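

Chloro in place of hydrogen on this aromatic carbon, between two ring nitrogen atoms, gives a 1.8-fold lower number from compound 2 to compound 3 (0.26 log units; within the scatter) in this assay. Compound 2 and compound 3 therefore cannot be told apart by this measurement, which shows that this carbon can carry a chloro group while the growth-inhibition number stays within the scatter of the hydrogen compound. No measurement shown here offers an explanation for this result.

The compounds shown have only hydrogen or chloro on this carbon, so what an amine or a methoxy group there would do remains open. A single step also cannot show whether the same exchange would give a similar result on another carbon of the shared core.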